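The source may hold more compounds than are shown below. What is called first, only, known or untested is meant among the compounds shown, and "the series" means these compounds.

Compound 2 `Nc1ccc(-c2cc(-c3ccc(C(F)(F)F)cc3)n[nH]2)cc1` is the point of departure. Among the compounds with values here, in a functional assay on NCI-H460 cells (Homo sapiens) for inhibition, read by MTT assay, with a stated time of 48 h (a higher number here means a weaker inhibitor of growth, a lower number a stronger inhibitor of growth), compound 2 gives 21500 nM, which sits at the lower end of the two numbers measured so far. Within the data shown here, its only neighbour is compound 1 `Nc1ccc(-c2cc(-c3ccccc3)n[nH]2)cc1`, which in this assay gives 26700 nM; the step of a 1.2-fold lower number from compound 1 to compound 2 (0.09 log units; within the scatter) is within the scatter, so the two compounds cannot be told apart on this assay.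

Compound 3 `Oc1ccc(-c2cc(-c3ccc(C(F)(F)F)cc3)n[nH]2)cc1` has not been measured. It differs from compound 2 by hydroxy in place of amino on an aromatic carbon. Among the measured compounds shown here, no measured step touches this position or this exchange: the one step recorded, from compound 1 to compound 2, concerns trifluoromethyl in place of hydrogen elsewhere on the molecule, and it was within the scatter. There is therefore no basis in the present numbers for expecting a shift beyond the scatter in this assay in either direction; the expectation for compound 3 is a number close to that of compound 2, the estimated step being a 1.1-fold lower number from compound 2 to compound 3 (0.03 log units; within the scatter). Compound 3 is accordingly estimated at 20000 nM, with a range from 7000 nM to 60000 nM.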

Compound 3, concentration for 50% growth inhibition: 20100 nM
Compound 3: middle estimate off by 1.0-fold (0.00 log units), on the low side, and the stated range covers the measured number.
By their numbers in this assay, from the lowest: compounds 3, 2 and 1 (each within the scatter of the next).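

Within the data shown here, compound 3 gives the first reading at this place, on a six-membered aromatic ring of carbon only and para to a large group, since the earlier step concerned trifluoromethyl elsewhere on the molecule. In this assay, the change from 4-aminophenyl to 4-hydroxyphenyl gives a 1.1-fold lower number from compound 2 to compound 3 (0.03 log units; within the scatter), so compound 2 and compound 3 cannot be told apart, and amino is not needed here for growth inhibition at this level, since hydroxy serves as well in the presence of the 4-trifluoromethylphenyl group. Nothing available explains why the two groups cannot be told apart in this assay.

The compounds shown leave open whether a methoxy, a dimethylamino, a carboxylic acid or an acetamide group at this place would move the number beyond the scatter, or whether any group here can do so at all. They also leave open whether hydroxy would behave the same way on the core of compound 1, which lacks trifluoromethyl.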